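Sulfonamide nitrogen substitution and maximal response at GPR27

A few compounds are considered here, and "the series" means these few. Any claim that something is new, unique, unknown or untested is made for them only; others in the source may bear on it.

Compounds measured so far:
- compound 1 `O=C(Nc1ccc(Cl)cc1Cl)c1ccc(S(=O)(=O)Nc2ccccc2)cc1`: "not determined" (no result reported)
- compound 2 `CN(c1ccccc1)S(=O)(=O)c1ccc(NC(=O)c2ccc(Cl)cc2Cl)cc1`: 50%
- compound 3 `Cc1cc(Br)ccc1C(=O)Nc1ccc(S(=O)(=O)Nc2ccccc2)cc1`: 103%

In a functional assay on HEK293 cells for agonist activity at probable G-protein coupled receptor 27 (Homo sapiens), read by a luciferase reporter and beta-arrestin recruitment, with a stated time of 10 min (a lower number here means a smaller maximal response, a higher number a larger maximal response), compound 2 gives 50%, the lowest of the two numbers available. Compound 3 stands well above it in this assay, with a gap beyond the usual scatter; compound 1 is reported as "not determined" (no result reported) in this assay, so it cannot be placed.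

Compound 4 `O=C(Nc1ccc(S(=O)(=O)Nc2cccc(Cl)c2)cc1)c1ccc(Cl)cc1Cl` is not yet measured. It differs from compound 2 in one place: (3-chlorophenyl)amino in place of methyl(phenyl)amino on a sulfonyl sulfur. The (3-chlorophenyl)amino group enters with one hydrogen-bond donor where the methyl(phenyl)amino group had none.

Among the compounds with values here, no step between measured compounds covers this change directly. Still, compound 3, which also carries an unsubstituted nitrogen on its sulfonyl sulfur, gives 103%, while compound 2 with the methyl(phenyl)amino group gives 50%. Since these two compounds also differ elsewhere, the comparison is only suggestive. An upward step in this assay is therefore expected, estimated as a number 28 percentage points higher from compound 2 to compound 4 (beyond the scatter). Compound 4 is expected to reach 78%, with a range from 45% to 110%.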

Compound 4, largest response reached (Emax), in percent of the reference or control that the assay uses: 40%
For compound 4 the middle estimate is 38 percentage points above the measured one; the whole stated range lies above it.
By their numbers in this assay, from the lowest: compounds 4 and 2 (each within the scatter of the next); then compound 3.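

In this assay, placing (3-chlorophenyl)amino in place of methyl(phenyl)amino on a sulfonyl sulfur gives a number 10 percentage points lower from compound 2 to compound 4 (within the scatter). On this core, then, a group with one hydrogen-bond donor at this place does not separate from a group with none, so the donor alone does not raise the maximal response in this pair. No measured evidence bears on the reason for this result.

The step swaps the methyl group and adds the chlorine in a single move, and the steps to compound 1, which would divide the two changes, cannot be read. Also open, on these data alone, is how the response would behave with a different group on the sulfonyl sulfur, such as benzylamino or morpholine.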